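The source may report more compounds than this note shows. Statements on the series, on what has been measured and on what is new or still open speak of the compounds shown alone.

Measured compounds:
compound 1, `O=S(=O)(Nc1ccc(-c2nc3cc(NS(=O)(=O)c4cccs4)ccc3o2)cc1)c1cccs1`: 40000 nM in an assay on cells for inhibition of HSP60/HSP10 (Homo sapiens), with a stated time of 60 min; on this read-out higher numbers stand for weaker inhibition and lower numbers for stronger inhibition
compound 2, `O=S(=O)(Nc1ccc2oc(-c3ccccc3)nc2c1)c1ccc(Cl)cc1`: > 100000 nM in this assay

Compound 1 carries a thiophene sulfonamide at each end of its core, and in this assay compound 1 gives 40000 nM, a weak inhibition but a measured number. Compound 2 is different in kind: in this assay compound 2 gives > 100000 nM, which is a limit of the assay and not a number. Compound 2 therefore sits at the limit of > 100000 nM in this assay, at which 1 of the 2 values shown sits.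

Compound 3, `O=S(=O)(Nc1ccc2oc(-c3ccccc3)nc2c1)c1cccs1`, has not yet been measured. The change from compound 2 is thiophen-2-yl in place of 4-chlorophenyl on a sulfonyl sulfur. Among the measured compounds shown here, because compound 2 gives only > 100000 nM there is no measured step to anchor this change, and the two measured compounds differ in more than one place, so their values can be compared but not tied to the single change. The step expected is an at least 1.2-fold lower number from compound 2 to compound 3 (0.09 log units; that floor lies within the scatter), and it is taken as modest, with the direction uncertain. Compound 3 is estimated at 80000 nM, within a range from 25000 nM to 300000 nM, and a limit rather than a number is a real possibility.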

Compound 3, half-maximal inhibitory concentration: 90000 nM
Beside the measured number, compound 3's estimate is 1.1-fold (0.05 log units) below it, and the stated range covers the measured number.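

With thiophen-2-yl in place of 4-chlorophenyl on a sulfonyl sulfur, this assay now yields a measured number, and the change reads as an at least 1.1-fold lower number from compound 2 to compound 3 (0.04 log units; that floor lies within the scatter). Compound 2 remains a limit of the assay and not a number, so this step has only a floor and its full size cannot be read: the limit of > 100000 nM in this assay, at which 1 of the 3 values shown sits. The measured pair gives a firmer reading at a different place, where hydrogen in place of ((thiophen-2-yl)sulfonyl)amino on an aromatic carbon gives a 2.3-fold higher number from compound 1 to compound 3 (0.35 log units; beyond the scatter), so this group goes with the stronger inhibition of the two, though the step is modest.

The compounds shown leave open whether another group on the sulfonyl sulfur, such as a methyl or a 4-methoxyphenyl, would give a number like that of thiophen-2-yl or a limit like that of 4-chlorophenyl. They also leave open whether a simple amine or a carboxylic acid on that aromatic carbon would match the ((thiophen-2-yl)sulfonyl)amino group, or whether that sulfonamide is needed in full.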